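The compounds below may be only part of what the source reports. "The series", "measured", "known", "first", "only" and "open" are said of these compounds alone.

The series shares a single core, shown in compound 1 `CCC[C@H](CO)Nc1nc(C)nc2c1c(C)nn2-c1ccc(OC)cc1C`, which in a functional assay on CHO cells for antagonist activity at corticotropin-releasing factor receptor 1 (Homo sapiens), read by cAMP accumulation (on this read-out higher numbers stand for weaker inhibition and lower numbers for stronger inhibition), gives compound 1 a value of 76 nM. Compound 2 `CCC(CC)Nc1nc(C)nc2c1c(C)nn2-c1ccc(OC)cc1C` carries a plain hydrocarbon branch in place of the hydroxymethyl-bearing one, and in this assay compound 2 gives 42 nM; the change runs a 1.8-fold lower number from compound 1 to compound 2 (0.26 log units; within the scatter). Compound 3 `CCCC(CCOC)Nc1nc(C)nc2c1cnn2-c1ccc(OC)cc1C` lacks the methyl on the five-membered part of the core and bears a longer, ether-containing branch on the ring nitrogen; in this assay compound 3 gives 132 nM. Among the three measured numbers compound 3 stands highest: its gap to compound 1 lies within the scatter, while its gap to compound 2 lies beyond it.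

Compound 4 `CCC(CC)Nc1nc(C)nc2c1cnn2-c1ccc(OC)cc1C` keeps the core of compound 3 and differs only at the amine branch: pentan-3-yl in place of 1-(2-methoxyethyl)butyl on a nitrogen on an aromatic ring. Within the data shown here, the one measured step that bears on this change is the one from compound 1 to compound 2, where the same pentan-3-yl group replaced an oxygen-bearing branch and the number moved slightly lower, within the scatter. Compound 2 also shows that pentan-3-yl on a methylated core gives the lowest number seen. For compound 4 the step is therefore expected to be a 2.0-fold lower number from compound 3 to compound 4 (0.31 log units; beyond the scatter), a modest move to a lower number. Compound 4 is estimated at 65 nM, with a range from 25 nM to 160 nM.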

Compound 4, inhibition constant: 85 nM
Compound 4: middle estimate off by 1.3-fold (0.12 log units), on the low side, and the stated range covers the measured number.
By their numbers in this assay, from the lowest: compounds 2, 1, 4 and 3 (each within the scatter of the next, the first and the last beyond it).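

Within this assay, the change from 1-(2-methoxyethyl)butyl to pentan-3-yl on the core without the methyl gives a 1.6-fold lower number from compound 3 to compound 4 (0.19 log units; within the scatter) and so does not separate these two branches. With a 1.8-fold lower number from compound 1 to compound 2 (0.26 log units; within the scatter) on the methylated core, this makes two exchanges of an oxygen-bearing branch for pentan-3-yl, and neither leaves the scatter. The new pair also gives the first single-place reading of the core methyl: hydrogen in place of methyl on the aromatic carbon gives a 2.0-fold higher number from compound 2 to compound 4 (0.31 log units; beyond the scatter) and lies beyond the scatter, so in this pair the methyl, not the amine branch, accounts for the clearer difference, although nothing shown explains either step. The compounds shown leave open whether the methyl step holds when a 1-(hydroxymethyl)butyl or 1-(2-methoxyethyl)butyl branch sits on the nitrogen, and whether ethyl or chlorine on that aromatic carbon would read like methyl or like hydrogen. They also leave open whether a branch carrying a primary amine, a carboxylic acid or a longer chain would separate from pentan-3-yl.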